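Swapping Nitro for Bromo on the Central Ring

A few compounds are considered here, and "the series" means these few. Any claim that something is new, unique, unknown or untested is made for them only; others in the source may bear on it.

Compound 1 `COc1ccc(-c2ccc(C(=O)N[C@H](C)CCCc3cccnc3)cc2Br)cc1OC`: 180 nM
Compound 2 `COc1ccc(-c2ccc(C(=O)NCCCCc3cccnc3)cc2OC)cc1OC`: 300 nM
Compound 3 `COc1ccc(-c2ccc(C(=O)NCCCCc3cccnc3)cc2[N+](=O)[O-])cc1OC`: 200 nM

All three were tested in an assay (Canis lupus familiaris) for binding affinity to platelet-activating factor receptor (Homo sapiens), read by radioligand binding; a lower number here means a stronger inhibitor, a higher number a weaker inhibitor. Compound 3 gives the second highest of the three numbers; compound 1 lies nearest and compound 2 furthest, both within the scatter. Compound 4 `COc1ccc(-c2ccc(C(=O)NCCCCc3cccnc3)cc2Br)cc1OC` has not yet been measured; it differs from compound 3 by bromo in place of nitro on an aromatic carbon. Within the data shown here, the only single-site step measured so far, a 1.5-fold lower number from compound 2 to compound 3 (0.18 log units; within the scatter), shows that exchanging the group at this position barely moved the number. Compound 1 also carries a bromo group but differs elsewhere in the molecule; its value and that of compound 3 sit within the scatter of each other. No step beyond the scatter is therefore expected. Compound 4 is estimated at 200 nM, with a range of 90 nM to 450 nM. The expected step is no change at the digits printed from compound 3 to compound 4 (within the scatter).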

Compound 4, half-maximal inhibitory concentration: 220 nM
The estimate for compound 4 lay 1.1-fold (0.04 log units) below the measured number, and the stated range covers the measured number.
By their numbers in this assay, from the lowest: compounds 1, 3, 4 and 2 (each within the scatter of the next).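

The step of a 1.1-fold higher number from compound 3 to compound 4 (0.04 log units; within the scatter) and the step of a 1.4-fold lower number from compound 2 to compound 4 (0.13 log units; within the scatter) show that methoxy, nitro and bromo cannot be told apart on this aromatic carbon, although bromo has 1 heavy atom and nitro has 3. With a 1.2-fold higher number from compound 1 to compound 4 (0.09 log units; within the scatter) as the step for hydrogen in place of methyl on the chain, that site also stays within the scatter. Nothing measured here explains why these groups read alike. As far as these compounds go, whether an amine or a carboxylic acid on this aromatic carbon would also stay within the scatter remains open, as does the effect of a longer chain in place of that methyl.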